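A few compounds are considered here, and "the series" means these few. Any claim that something is new, unique, unknown or untested is made for them only; others in the source may bear on it.

Measured compounds:
- compound 1, `CNc1nc(Cl)nc(N[C@@H](C)c2ccccc2)n1`, 26900 nM
- compound 2, `CC[C@H](C)Nc1nc(Cl)nc(N[C@@H](C)c2ccccc2)n1`, 14100 nM
- compound 3, `CCCN(CCC)c1nc(Cl)nc(N[C@@H](C)c2ccccc2)n1`, 100 nM

In an ADME assay on the whole organism for inhibition, with Echinochloa crus-galli var. formosensis as the target, with a stated time of 4 days (on this read-out lower numbers stand for stronger inhibition and higher numbers for weaker inhibition), compound 3 holds the lowest number of the three, with compound 2 as its nearest neighbour and compound 1 furthest away, both far beyond the scatter. The two steps reaching compound 3 are the ones that matter here: a 270-fold lower number from compound 1 to compound 3 (2.43 log units; beyond the scatter) and a 140-fold lower number from compound 2 to compound 3 (2.15 log units; beyond the scatter), while a 1.9-fold lower number from compound 1 to compound 2 (0.28 log units; within the scatter) is small. Compound 4, `CCCCNc1nc(Cl)nc(N[C@@H](C)c2ccccc2)n1`, differs from compound 3 by the change (butylamino in place of dipropylamino on an aromatic carbon). This undoes the kind of change that produced the two large drops, replacing the dipropylamino group with another alkylamino group carrying one hydrogen-bond donor, as in compound 1 and compound 2. Compound 4 is therefore expected to give a much higher number than compound 3 in this assay, with the step estimated as an 80-fold higher number from compound 3 to compound 4 (1.90 log units; beyond the scatter). The estimate for compound 4 in this assay is 8000 nM, with a range from 2000 nM to 30000 nM.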

Compound 4, half-maximal inhibitory concentration: 12900 nM
Compound 4: the middle estimate sits 1.6-fold (0.21 log units) below what was measured, and the stated range covers the measured number.
By their numbers in this assay, from the lowest: compound 3; then compounds 4, 2 and 1 (each within the scatter of the next, the first and the last beyond it).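

In this assay, a 130-fold higher number from compound 3 to compound 4 (2.11 log units; beyond the scatter) shows that a single butyl chain on this nitrogen does not give what dipropylamino gives, so chain length on a secondary amine does not account for the low number of compound 3. The shape of the chain makes no readable difference here, since a 1.1-fold lower number from compound 2 to compound 4 (0.04 log units; within the scatter) stays within the scatter. Going from methyl to butyl on this nitrogen brings only a 2.1-fold lower number from compound 1 to compound 4 (0.32 log units; beyond the scatter) and is a modest step beside the large one to dipropylamino.

Nothing available explains why dipropylamino stands apart from the other groups at this position. As far as these compounds go, whether the low number needs two propyl chains, or would also appear with diethylamino or dibutylamino on the same aromatic carbon, remains open.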